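Diacylhydrazine series: a bromo-to-dichloro swap on one aroyl ring

The source may hold more compounds than are shown below. What is called first, only, known or untested is meant among the compounds shown, and "the series" means these compounds.

Three members of the series have numbers in an assay on cells for agonist activity at ecdysone receptor (Bombyx mori), read by a luciferase reporter, with a stated time of 24 h; a lower number here means that less compound is needed, a higher number that more compound is needed for the effect. Compound 1 `CC(C)(C)N(NC(=O)c1ccccc1)C(=O)c1ccccc1C(F)(F)F` gives 631 nM. Compound 2 `Cc1cc(C)cc(C(=O)N(NC(=O)c2ccccc2)C(C)(C)C)c1` gives 69.2 nM. Compound 3 `CC(C)(C)N(NC(=O)c1ccccc1Br)C(=O)c1ccccc1Cl` gives 316 nM, which stands second highest of the three: against compound 1 the gap is within the scatter, while compound 2 sits a clear distance lower. The next member, compound 4 `CC(C)(C)N(NC(=O)c1cccc(Cl)c1Cl)C(=O)c1ccccc1Cl`, is not yet measured and differs from compound 3 in one place only: 2,3-dichlorophenyl in place of 2-bromophenyl on a carbonyl carbon. Going by the values given here, no measured pair in the set isolates this change, so nothing here fixes its size. The expectation is a step from compound 3 to compound 4 of a 1.3-fold lower number from compound 3 to compound 4 (0.10 log units; within the scatter), that is, no change beyond the scatter. Compound 4 is thus estimated at 250 nM, within 100 nM to 800 nM.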

Compound 4, half-maximal effective concentration: 9.33 nM
Compound 4: middle estimate off by 27-fold (1.43 log units), on the high side, and the stated range ends above it.
By their numbers in this assay, from the lowest: compound 4; then compound 2; then compounds 3 and 1 (each within the scatter of the next).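

In this assay, going by these compounds alone, 2,3-dichlorophenyl in place of 2-bromophenyl on a carbonyl carbon gives a 34-fold lower number from compound 3 to compound 4 (1.53 log units; beyond the scatter) and provides the first single-place step. This place is therefore highly sensitive to the choice of aryl group, with the other aroyl ring held constant. Nothing measured here accounts for the size of the step.

The swap removes bromine and introduces two chlorines at once, so the contribution of each remains unresolved. Also open, as far as these compounds go, is how this place responds to an amine or a carboxylic acid on the ring.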